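The source may report more compounds than this note shows. Statements on the series, on what has been measured and on what is new or still open speak of the compounds shown alone.

Compound 1, `COc1ccc(/C=C2\NC(=O)N(CCCCN3CCN(c4cccc(Cl)c4Cl)CC3)C2=O)cc1OC`: 0.8 nM. Compound 2, `COc1ccc(/C=C2\NC(=O)N(CCCCN3CCN(c4ncccn4)CC3)C2=O)cc1OC`: 933 nM. Compound 3, `COc1ccc(/C=C2\NC(=O)N(CCCN3CCN(c4cccc(Cl)c4Cl)CC3)C2=O)cc1OC1CCCC1`: 380 nM.

These three compounds were measured in an assay on CHO cells for displacement of a labelled ligand from 5-hydroxytryptamine receptor 7 (Homo sapiens), read by scintillation counting, with a stated time of 60 min; a higher number here means a weaker inhibitor, a lower number a stronger inhibitor. Compound 1 gives 0.8 nM, and replacing its 2,3-dichlorophenyl by pyrimidin-2-yl, the change (pyrimidin-2-yl in place of 2,3-dichlorophenyl on an amine nitrogen in a ring), leads to compound 2 with 933 nM, a step of a 1200-fold higher number from compound 1 to compound 2 (3.07 log units; beyond the scatter). Compound 3 differs from compound 1 elsewhere in the molecule; the difference between the two cores is not broken down here, and compound 3 gives 380 nM in this assay, which is far weaker than compound 1 and somewhat stronger than compound 2.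

Compound 4, `COc1ccc(/C=C2\NC(=O)N(CCCN3CCN(c4ncccn4)CC3)C2=O)cc1OC1CCCC1`, is not yet measured in this assay. It carries the same change as seen between compound 1 and compound 2, (pyrimidin-2-yl in place of 2,3-dichlorophenyl on an amine nitrogen in a ring), now made on the core of compound 3. Among the measured compounds shown here, the only measured example of this change is the very large step from compound 1 to compound 2, and no further pairs are available to show whether the step keeps its size on a different core. Since compound 3 already starts from 380 nM, the same change is expected to push compound 4 to a much higher number. The step from compound 3 to compound 4 is estimated at a 110-fold higher number from compound 3 to compound 4 (2.02 log units; beyond the scatter), somewhat smaller than the one measured, because the starting point in a 1200-fold higher number from compound 1 to compound 2 (3.07 log units; beyond the scatter) was much stronger. Compound 4 is therefore expected to give about 40000 nM, within 5000 nM to 500000 nM.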

Compound 4, inhibition constant: > 1000 nM
Compound 4: only a limit was reported; the forecaster's own chance of this, stated with the estimate: 55%; the middle value does not contradict the limit.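

In this assay compound 4 gives > 1000 nM, which is a limit of the assay and not a number. On this second core, pyrimidin-2-yl in place of 2,3-dichlorophenyl on an amine nitrogen in a ring gives an at least 2.6-fold higher number from compound 3 to compound 4 (0.42 log units; beyond the scatter), so the change moves the number in the same direction on both cores, and the step is beyond the scatter even at its smallest reading. This does not show that the step keeps its size from one core to the other, and with only two cores it sets no rule for the series, since the second step is open-ended and may be smaller than, similar to or larger than the first: the same change on two cores in this assay, a 1200-fold higher number (3.07 log units; beyond the scatter) from compound 1 to compound 2 and an at least 2.6-fold higher number (0.42 log units; beyond the scatter) from compound 3 to compound 4; the limit leaves it open whether they differ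

The compounds shown carry only two groups on that ring nitrogen, so they leave open where a phenyl with a single chlorine, an unsubstituted phenyl or a pyridin-2-yl would fall between 2,3-dichlorophenyl and pyrimidin-2-yl. They also leave open which part of the difference between the core of compound 1 and the core of compound 3 accounts for the gap between those two dichlorophenyl compounds, and whether that part alters the size of the step.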